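Hydroxy to methoxy at the limit of the cytotoxicity read-out

This account rests on a few compounds, and the source may have more. Where it says the series, first, only, none or still open, it means among the compounds named here.

Measured in a functional assay on cells (Homo sapiens) for cytotoxicity, read by resazurin assay, with a stated time of 72 h; on this read-out higher numbers stand for weaker inhibition and lower numbers for stronger inhibition:
- compound 1 `COc1cc(/C=C/C(=O)OCCCCCCO[N+](=O)[O-])ccc1O`: > 50000 nM
- compound 2 `O=C(/C=C/c1ccc(OCCCCO[N+](=O)[O-])c(O)c1)OCCCCO[N+](=O)[O-]`: > 50000 nM
- compound 3 `O=C(/C=C/c1ccc(OCCCCCCO[N+](=O)[O-])c(O)c1)OCCCCCCO[N+](=O)[O-]`: > 50000 nM

Each of these three entries is a limit of the assay and not a number. Going by the values given here, the series so far stands at the limit of > 50000 nM in this assay, at which 3 of the 3 values shown sit, so no order can be drawn among compound 1, compound 2 and compound 3.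

Compound 3 gives > 50000 nM in this assay, and this is a limit. The next compound to be read is compound 4 `COc1cc(/C=C/C(=O)OCCCCCCO[N+](=O)[O-])ccc1OCCCCCCO[N+](=O)[O-]`. It differs from compound 3 by methyl in place of hydrogen on an oxygen on an aromatic ring, the change being hydroxy to methoxy, with methyl in place of hydrogen on an oxygen on an aromatic ring.

Among the compounds with values here, no step between measured compounds is available to size this change. Within the data shown here, the only guide is that all three compounds in hand sit at the same limit, and none of them gives a number. No shift beyond the scatter is expected in this assay, in either direction, and the expected a number no higher from compound 3 to compound 4 (the limit leaves the size open) should be read in that light. The assay is expected to report a limit again for compound 4. As a number, compound 4 is estimated at 50000 nM, within an expected range of 25000 nM to 100000 nM.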

Compound 4, half-maximal inhibitory concentration: > 50000 nM
Compound 4: only a limit was reported; the forecaster's own chance of this, stated with the estimate: 85%; the middle value sits exactly at the limit.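

In this assay compound 4 gives > 50000 nM, which is a limit. The steps from compound 3 and from compound 1 to compound 4 cannot be read, because every value shown is a limit: the limit of > 50000 nM in this assay, at which 4 of the 4 values shown sit. The compounds shown leave open whether any of these changes shifts the read-out, and what number any compound would give.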